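Same Atoms, One Stereocentre Drawn Differently

This account rests on a few compounds, and the source may have more. Where it says the series, first, only, none or still open, it means among the compounds named here.

In a functional assay on HCT-116 cells (Homo sapiens) for antiproliferative activity, read by MTT assay, with a stated time of 48 h (a higher number here means a weaker inhibitor, a lower number a stronger inhibitor), compound 1 `CCCCCCCCCC(CCO)n1cnc2c(Cl)ncnc21` gives 890 nM. Compound 2 `CCCCCCCCC[C@H](CCOS(C)(=O)=O)n1cnc2c(Cl)ncnc21` gives 9480 nM, the higher of the two numbers, which makes it the weaker inhibitor, and the gap between them lies beyond the scatter of repeated measurements. Compound 3 `CCCCCCCCCC(CCOS(C)(=O)=O)n1cnc2c(Cl)ncnc21` has not yet been measured. Its difference from compound 2 is the two compounds have the same atoms and bonds; at least one stereo element is drawn with a configuration in one of them and without one in the other: 1 of 1 stereo elements differ; a stereocentre at a saturated chain carbon is drawn R in compound 2 and without a configuration in compound 3: the two compounds have the same atoms and bonds, and a stereocentre at a saturated chain carbon is drawn R in compound 2 and without a configuration in compound 3. Going by the values given here, no two measured compounds here differ in this way alone, so the data do not show how much this stereocentre matters. With atoms and bonds unchanged, the natural expectation in this assay is no step beyond the scatter, in either direction. The estimated change a 1.3-fold lower number from compound 2 to compound 3 (0.10 log units; within the scatter) is therefore expected to be small. For compound 3 the estimate is 7500 nM, with the measured number expected to fall between 3000 nM and 18000 nM.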

Compound 3, half-maximal inhibitory concentration: 5440 nM
For compound 3 the middle estimate is 1.4-fold (0.14 log units) above the measured one; measured number inside the range.
By their numbers in this assay, from the lowest: compound 1; then compounds 3 and 2 (each within the scatter of the next).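

Whether this saturated chain carbon is drawn R or without a configuration makes no clear difference in this assay, where the result is a 1.7-fold lower number from compound 2 to compound 3 (0.24 log units; within the scatter). Going by these compounds alone, this is the first direct look at the stereocentre, and it gives no sign that the defined drawing changes the read-out, although a drawing without a configuration does not say which spatial form or forms the sample holds. The new compound also gives a first clean reading at the chain end, since methylsulfonyl in place of hydrogen on an oxygen on a saturated carbon is the one change behind a 6.1-fold higher number from compound 1 to compound 3 (0.79 log units; beyond the scatter), a modest weakening that lies beyond the scatter, while the only thing separating the two mesylate-bearing compounds is this: the fact that one of compounds 2 and 3 is drawn with a defined configuration and the other without, at the place where they differ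

The compounds shown leave open how a form drawn S at this carbon would compare, so the two spatial arrangements cannot yet be set against each other. They also leave open whether an acetyl group on the same oxygen, an amine at the end of the chain or a longer chain would keep or lose the activity seen with the free hydroxyl.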